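The compounds below may be only part of what the source reports. "The series", "measured", "known", "first", "only" and "open" are said of these compounds alone.

In a functional assay on the whole organism for inhibition, with Rattus norvegicus as the target, read by paw edema, at a dose of 100 mg/kg by the oral route (a lower number here means less inhibition, a higher number more inhibition at the dose given (going by the name of the read-out)), compound 3 `Cc1cccc(NC(=O)c2c(O)c3cccnc3n(-c3ccccc3)c2=O)c1` gives 14.2%, the highest of the three numbers; compound 1 `O=C(NCc1ccccc1)c1c(O)c2cccnc2n(-c2ccccc2)c1=O` gives 1.6%, and compound 2 `O=C(NN1CCOCC1)c1c(O)c2cccnc2n(-c2ccccc2)c1=O` gives -8.5%. The measured steps all change the group on the amide-type nitrogen: a number 12.6 percentage points higher from compound 1 to compound 3 (beyond the scatter), a number 22.7 percentage points higher from compound 2 to compound 3 (beyond the scatter), and a number 10.1 percentage points lower from compound 1 to compound 2 (beyond the scatter). Compound 4 `COc1ccccc1NC(=O)c1c(O)c2cccnc2n(-c2ccccc2)c1=O` follows the same route, with 2-methoxyphenyl in place of 3-methylphenyl on an amide-type nitrogen. Among the measured compounds shown here, no measured step exchanges one aromatic ring for another on that nitrogen, so the measured steps bear only loosely on this change. As both compound 3 and compound 4 keep an aromatic ring there, compound 4 is expected to stay close to compound 3, with a step of a number 4.2 percentage points lower from compound 3 to compound 4 (within the scatter) that lies within the scatter. Compound 4 is therefore estimated at 10%, in the range -5% to 25%.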

Compound 4, a percentage reported as inhibition, in the whole organism at one dose (the size of the read-out at that dose, not a potency): 8.1%
For compound 4 the middle estimate is 1.9 percentage points above the measured one; low and high end bracket the measured number.
By their numbers in this assay, from the lowest: compound 2; then compounds 1, 4 and 3 (each within the scatter of the next, the first and the last beyond it).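

Exchanging one aromatic ring for another on the amide-type nitrogen gives a number 6.1 percentage points lower from compound 3 to compound 4 (within the scatter) and so does not separate 3-methylphenyl from 2-methoxyphenyl. The other steps are a number 16.6 percentage points higher from compound 2 to compound 4 (beyond the scatter) and a number 6.5 percentage points higher from compound 1 to compound 4 (within the scatter) and so set 2-methoxyphenyl apart from morpholin-4-yl but not from benzyl, unlike 3-methylphenyl, whose step from benzyl lay beyond the scatter. No evidence at hand bears on these differences.

The compounds shown leave open what an amine or a carboxylic acid on that aromatic ring would do. They also leave open how a longer chain on that nitrogen would compare.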